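Diaryl urea series: aryl swap on the triazole nitrogen

The compounds below may be only part of what the source reports. "The series", "measured", "known", "first", "only" and "open" are said of these compounds alone.

Measured so far, in a functional assay on HepG2 cells (Homo sapiens) for inhibition, read by MTT assay, with a stated time of 72 h; a higher number here means a weaker inhibitor, a lower number a stronger inhibitor:
compound 1 `Cc1ccccc1-n1cc(COc2cccc(NC(=O)Nc3ccc(Cl)c(C(F)(F)F)c3)c2)nn1`: 3440 nM
compound 2 `O=C(Nc1cccc(OCc2cn(-c3ccc(F)cc3)nn2)c1)Nc1ccc(Cl)c(C(F)(F)F)c1`: 1350 nM

Compound 2 stands lowest of the two numbers. Within the data shown here, the only measured step is a 2.5-fold lower number from compound 1 to compound 2 (0.41 log units; beyond the scatter), where 4-fluorophenyl replaced 2-methylphenyl on the aromatic nitrogen. Compound 3 `COc1ccccc1-n1cc(COc2cccc(NC(=O)Nc3ccc(Cl)c(C(F)(F)F)c3)c2)nn1` differs from compound 2 by 2-methoxyphenyl in place of 4-fluorophenyl on an aromatic nitrogen. That step reverses the direction of the measured one, bringing in a 2-methoxyphenyl where compound 1 carried 2-methylphenyl; it is expected to move the number back toward compound 1 by a 2.1-fold higher number from compound 2 to compound 3 (0.32 log units; beyond the scatter), roughly the size of the measured step. Compound 3 is therefore estimated at 2800 nM, with a range of 1200 nM to 6500 nM.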

Compound 3, half-maximal inhibitory concentration: 11300 nM
For compound 3 the middle estimate is 4.0-fold (0.61 log units) below the measured one; the measured number lies above the stated range.
By their numbers in this assay, from the lowest: compound 2; then compound 1; then compound 3.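

The nitrogen substituent is more sensitive than the first step indicated: 2-methoxyphenyl in place of 4-fluorophenyl gives an 8.4-fold higher number from compound 2 to compound 3 (0.92 log units; beyond the scatter). The aromatic carbon substituent also matters, since methoxy in place of methyl gives a 3.3-fold higher number from compound 1 to compound 3 (0.52 log units; beyond the scatter), leaving 4-fluorophenyl lowest and 2-methoxyphenyl highest among these three compounds. No available evidence bears on the reason for this rise.

Still open, on these data alone, is how unsubstituted phenyl would read at this nitrogen. Also open, as far as these compounds go, is whether an amine or a carboxylic acid on the aryl ring would follow the methoxy or the methyl result.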